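The compounds below may be only part of what the source reports. "The series", "measured", "known", "first", "only" and "open" are said of these compounds alone.

Measured compounds in an assay on cells for inhibition of RAC-alpha serine/threonine-protein kinase (Homo sapiens), with a stated time of 1 h; a lower number here means a stronger inhibitor, a higher number a weaker inhibitor:
compound 1 `C[C@@H]1CC(=O)Nc2ncnc(N3CCC(c4nc(-c5ccc(F)c(C(F)(F)F)c5)cn4CCN4CCCC4)CC3)c21`: 39 nM
compound 2 `C[C@@H]1CC(=O)Nc2ncnc(N3CCC(c4nc(C(F)(F)F)cn4CCN4CCCC4)CC3)c21`: 2460 nM
compound 3 `C[C@@H]1CC(=O)Nc2ncnc(N3CCC(c4nc(C5CCOCC5)cn4CCN4CCCC4)CC3)c21`: 230 nM

Compound 3 stands second highest of the three numbers in this assay; compound 1 is nearest, with the step of a 5.9-fold higher number from compound 1 to compound 3 (0.77 log units; beyond the scatter), and compound 2 furthest, with the step of an 11-fold lower number from compound 2 to compound 3 (1.03 log units; beyond the scatter), both beyond the scatter. Compound 4 `C[C@@H]1CC(=O)Nc2ncnc(N3CCC(c4nc(CCC(F)(F)F)cn4CCN4CCCC4)CC3)c21` is not yet measured. It differs from compound 3 in one place: 3,3,3-trifluoropropyl in place of oxan-4-yl on an aromatic carbon.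

Going by the values given here, two measured steps bear on this change. The step of an 11-fold lower number from compound 2 to compound 3 (1.03 log units; beyond the scatter) shows the ring oxan-4-yl giving a far lower number than trifluoromethyl at this position, and the step of a 63-fold higher number from compound 1 to compound 2 (1.80 log units; beyond the scatter) shows trifluoromethyl giving the highest number of the set. The 3,3,3-trifluoropropyl of compound 4 is neither the ring of compound 3 nor the trifluoromethyl of compound 2, so a step upward in this assay from compound 3 is expected, of a size between the two, a 3.9-fold higher number from compound 3 to compound 4 (0.59 log units; beyond the scatter). Compound 4 is estimated at 900 nM, with a range from 300 nM to 3000 nM.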

Compound 4, half-maximal inhibitory concentration: 92 nM
Compound 4: middle estimate off by 9.8-fold (0.99 log units), on the high side; the whole stated range lies above it.
By their numbers in this assay, from the lowest: compound 1; then compound 4; then compound 3; then compound 2.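

In this assay, the ring is not needed at this position: a 2.5-fold lower number from compound 3 to compound 4 (0.40 log units; beyond the scatter) shows the open-chain 3,3,3-trifluoropropyl giving a lower number than oxan-4-yl, with the heavy-atom count unchanged. Fluorine in the substituent does not by itself give the high number of compound 2, since a 27-fold lower number from compound 2 to compound 4 (1.43 log units; beyond the scatter) separates two fluorinated groups on the same aromatic carbon. The 4-fluoro-3-(trifluoromethyl)phenyl group still gives the lowest number of the four, yet a 2.4-fold higher number from compound 1 to compound 4 (0.37 log units; beyond the scatter) is a modest step, so among these compounds an aromatic ring at this position is not required for a number close to that of compound 1.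

From the compounds shown here alone, whether a plain propyl chain, a longer fluorinated chain or a chain ending in an amine or a carboxylic acid would lower or raise the number remains open. Nothing available gives a reason for any of these steps.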